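A few compounds are considered here, and "the series" means these few. Any claim that something is new, unique, unknown or untested is made for them only; others in the source may bear on it.

Within the data shown here, in an ADME assay on the whole organism (Rattus norvegicus) for metabolic stability, at a dose of 1 mg/kg by the intravenous route (on this read-out higher numbers stand for a longer-lived compound and lower numbers for a shorter-lived compound), compound 2 `Cc1nnc(N2CCC(C(=O)N3N=CC[C@H]3c3cc(F)cc(F)c3)CC2)o1` gives 1.7 h and compound 1 `N#Cc1cnc(N2CCC(C(=O)N3N=CC[C@H]3c3cc(F)cc(F)c3)CC2)cn1` gives 1.9 h, so compound 2 stands level with the only other measured compound. Compound 3 `N#Cc1cc(N2CCC(C(=O)N3N=CC[C@H]3c3cc(F)cc(F)c3)CC2)ncn1` changes the group on an amine nitrogen in a ring: a group of 8 heavy atoms (5 carbon, 3 nitrogen; one six-membered aromatic ring with 2 hetero atoms) in place of a group of 6 heavy atoms (3 carbon, 2 nitrogen, 1 oxygen; one five-membered aromatic ring with 3 hetero atoms), on an amine nitrogen in a ring. Among the measured compounds shown here, the one measured step at this place is a 1.1-fold lower number from compound 1 to compound 2 (0.05 log units; within the scatter), which stays within the scatter. No step beyond the scatter is therefore expected in this assay. The estimated change is a 1.1-fold higher number from compound 2 to compound 3 (0.02 log units; within the scatter). For compound 3 the expected value is 1.8 h, with an estimated range of 1 h to 3.2 h.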

Compound 3, half-life: 1.65 h
Compound 3: the middle estimate sits 1.1-fold (0.04 log units) above what was measured, within the range that was stated.
By their numbers in this assay, from the lowest: compounds 3, 2 and 1 (each within the scatter of the next).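

In this assay, a third group on the amine nitrogen again gives no step beyond the scatter: a 1.0-fold lower number from compound 2 to compound 3 (0.01 log units; within the scatter) and a 1.2-fold lower number from compound 1 to compound 3 (0.06 log units; within the scatter). Exchanging one nitrile-bearing six-membered aromatic ring with 2 hetero atoms for another thus reads the same as exchanging the 5-methyl-1,3,4-oxadiazol-2-yl group for such a ring, in these three compounds only. Nothing measured here explains this result.

Open, on these data alone, is whether a non-aromatic group on this nitrogen, such as an acetyl group or a longer alkyl chain, would also leave the half-life level. Also open, as far as these compounds go, is whether it stays level when chlorine replaces fluorine on the shared core.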